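Fluoromethyl in Place of Methyl on a Dimethoxy Scaffold

The compounds below may be only part of what the source reports. "The series", "measured", "known", "first", "only" and "open" are said of these compounds alone.

Measured so far:
Compound 1, `COc1ccc(C(c2ccc(OC)c(OC)c2)[C@H](C)[C@@H](C)CO)cc1OC`, gives 67000 nM.
Compound 2, `COc1cc(C(c2ccc(O)c(OC)c2)[C@H](C)C(C)C)ccc1O`, gives 16000 nM.

Of the compounds shown here, two have been tested in a functional assay on HeLa cells (Homo sapiens) for cytotoxicity, read by WST assay, with a stated time of 48 h; on this read-out higher numbers stand for weaker inhibition and lower numbers for stronger inhibition. Compound 2 holds the lowest of the two numbers, and its nearest neighbour is compound 1, whose number is higher by a margin that goes beyond the usual scatter of repeated measurements. Within the data shown here, no single-point step between these two measured compounds is available, so only their two values can be compared.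

Compound 3, `COc1cc(C(c2ccc(O)c(OC)c2)[C@H](CF)C(C)C)ccc1O`, has not yet been measured. It differs from compound 2 in one place: fluoro in place of hydrogen on a saturated chain carbon, three bonds along the chain from two aromatic carbons. Among the measured compounds shown here, nothing among the measured compounds shows how this kind of change affects the read-out of this assay.

Since the change is small and touches no ring and no hydrogen-bond donor or acceptor, the expected step of a 1.1-fold lower number from compound 2 to compound 3 (0.03 log units; within the scatter) is none beyond the scatter. Compound 3 is therefore estimated at 15000 nM, with a range from 6000 nM to 40000 nM.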

Compound 3, half-maximal inhibitory concentration: 19000 nM
Estimate against measurement, compound 3: 1.3-fold (0.10 log units) below; the range from low to high includes it.
By their numbers in this assay, from the lowest: compounds 2 and 3 (each within the scatter of the next); then compound 1.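

Among these compounds, this is the first change at a single place that can be read. In this assay, turning methyl into fluoromethyl, with fluoro in place of hydrogen on a saturated chain carbon, three bonds along the chain from two aromatic carbons, gives a 1.2-fold higher number from compound 2 to compound 3 (0.07 log units; within the scatter). At this position, then, compound 3 cannot be told apart from compound 2, so this one fluorine atom leaves no detectable mark on the HeLa cell read-out, although a single pair cannot show how other groups would behave here. No supporting measurement is available to explain why the read-out holds steady.

What the compounds shown leave open is how far this tolerance extends: a trifluoromethyl group, an aminomethyl group or a longer chain such as ethyl at the same carbon might read the same or might move the number beyond the scatter. As far as these compounds go, it also remains open whether fluoro in place of hydrogen would read alike on another saturated chain carbon of the shared core.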